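Branched chain swap on a thiourea benzimidazole

The compounds below may be only part of what the source reports. "The series", "measured", "known", "first", "only" and "open" are said of these compounds alone.

Compound 1 `CC(C)[C@H](NC(=S)Nc1cc(C(F)(F)F)cc(C(F)(F)F)c1)c1nc2ccccc2[nH]1` is the weakest of the three measured compounds in a functional assay on MCF7 cells (Homo sapiens) for cytotoxicity, read by MTT assay (a lower number here means a stronger inhibitor, a higher number a weaker inhibitor), where compound 1 gives 24300 nM. Its nearest neighbour, compound 3 `CC(C)[C@@H](NC(=S)Nc1cc(C(F)(F)F)cc(C(F)(F)F)c1)c1nc2ccccc2[nH]1`, gives 16400 nM and the move a 1.5-fold lower number from compound 1 to compound 3 (0.17 log units; within the scatter) rests only on (the fact that compounds 1 and 3 differ only in the configuration as drawn). Compound 2 `CC(C)C[C@@H](NC(=S)Nc1ccccc1)c1nc2ccccc2[nH]1` gives 11900 nM. Compound 4 `CC(C)C[C@H](NC(=S)Nc1cc(C(F)(F)F)cc(C(F)(F)F)c1)c1nc2ccccc2[nH]1` has not been measured; it differs from compound 1 by isobutyl in place of isopropyl on a saturated chain carbon bound to an amide-type nitrogen and an aromatic carbon. Going by the values given here, no measured step isolates this change: compound 2 carries the isobutyl chain but also a different aryl group, so its value and that of compound 1 only loosely bound the outcome. The step is therefore expected to be small, near the scatter, a 1.4-fold lower number from compound 1 to compound 4 (0.16 log units; within the scatter). Compound 4 is estimated at 17000 nM, between 7000 nM and 40000 nM.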

Compound 4, half-maximal inhibitory concentration: 16300 nM
Compound 4: the middle estimate sits 1.0-fold (0.02 log units) above what was measured; low and high end bracket the measured number.
By their numbers in this assay, from the lowest: compounds 2, 4, 3 and 1 (each within the scatter of the next, the first and the last beyond it).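

Going by these compounds alone, with the aryl group and the rest of the core held constant, this is the first direct reading of this swap at the saturated chain carbon: in this assay, isobutyl in place of isopropyl gives a 1.5-fold lower number from compound 1 to compound 4 (0.17 log units; within the scatter). The added carbon therefore produces no difference that can be told apart from repeat-measurement scatter. Nothing available explains this result. Still open, as far as these compounds go, is whether a longer chain, a cyclohexyl ring or a chain ending in an amine or a carboxylic acid at this carbon would shift the number beyond the scatter.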